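A few compounds are considered here, and "the series" means these few. Any claim that something is new, unique, unknown or untested is made for them only; others in the source may bear on it.

Compound 1, with the structure `O=C(OCc1ccccc1)c1cccc(=O)[nH]1`, is the reference point here. For the measured compounds named here, in an assay on isolated protein for inhibition of matrix metalloproteinase-9 (Homo sapiens) (a lower number here means a stronger inhibitor, a higher number a weaker inhibitor), compound 1 gives 69000 nM, the second highest of the three numbers measured so far. Compound 2 `O=C(OCc1ccccc1Br)c1cccc(=O)[nH]1` gives 59000 nM, and compound 3 `COc1ccc(COC(=O)c2cccc(=O)[nH]2)cc1` gives 100000 nM. The two steps already seen, a 1.2-fold lower number from compound 1 to compound 2 (0.07 log units; within the scatter) and a 1.4-fold higher number from compound 1 to compound 3 (0.16 log units; within the scatter), both stay within the scatter of the assay. Compound 4 `O=C(OCc1cccc(Oc2ccccc2)c1)c1cccc(=O)[nH]1` differs from compound 1 by phenoxy in place of hydrogen on an aromatic carbon. Going by the values given here, no measured step involves a phenoxy group, so the two known steps bear on it only loosely; because both a 1.2-fold lower number from compound 1 to compound 2 (0.07 log units; within the scatter) and a 1.4-fold higher number from compound 1 to compound 3 (0.16 log units; within the scatter) changed little, a step of about a 1.4-fold lower number from compound 1 to compound 4 (0.14 log units; within the scatter) is expected, with wide uncertainty. For compound 4 the estimate is 50000 nM, within a range of 15000 nM to 150000 nM.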

Compound 4, half-maximal inhibitory concentration: > 150 nM
Compound 4: a limit, no number; the forecaster's own chance of this, stated with the estimate: 20%; the middle value lies beyond the limit too.
By their numbers in this assay, from the lowest: compounds 2, 1 and 3 (each within the scatter of the next).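

Compound 4 gives > 150 nM, which is a limit and not a number. For the compounds shown here, no step from compound 1 to compound 4 can be read from it. The compounds shown leave open how phenoxy in place of hydrogen changes the number in this assay.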